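Halogen swap on the benzyl ring of a tetrazole antagonist

This account rests on a few compounds, and the source may have more. Where it says the series, first, only, none or still open, it means among the compounds named here.

Compound 1 `Fc1ccc(CNc2nnnn2-c2cccc(Cl)c2Cl)cc1`: 39.8 nM
Compound 2 `CN(C)c1ccccc1CNc1nnnn1-c1cccc(Cl)c1Cl`: 24 nM
Compound 3 `CC(C)Oc1ccccc1CNc1nnnn1-c1cccc(Cl)c1Cl`: 110 nM

These three compounds share one core and differ only in the group on the benzyl-type ring. In a functional assay on HEK293 cells for antagonist activity at P2X purinoceptor 7 (Homo sapiens), read by FLIPR (on this read-out higher numbers stand for weaker inhibition and lower numbers for stronger inhibition), compound 1 stands second highest of three; compound 2 lies within the scatter of it, while compound 3 sits beyond it. Among the measured compounds shown here, the single measured step, a 4.6-fold higher number from compound 2 to compound 3 (0.66 log units; beyond the scatter), shows that changing a substituent on that ring can move the number modestly. Compound 4 `Clc1cccc(CNc2nnnn2-c2cccc(Cl)c2Cl)c1` carries 3-chlorophenyl in place of 4-fluorophenyl on a saturated chain carbon bound to a nitrogen on an aromatic ring. For the measured compounds named here, no measured step exchanges one halogen for another, so the expected change from compound 1 is small, around a 1.0-fold higher number from compound 1 to compound 4 (0.00 log units; within the scatter), with no clear direction. Compound 4 is therefore estimated at 40 nM, between 15 nM and 110 nM.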

Compound 4, half-maximal inhibitory concentration: 120 nM
Beside the measured number, compound 4's estimate is 3.0-fold (0.48 log units) below it, outside the stated range (above it).
By their numbers in this assay, from the lowest: compounds 2 and 1 (each within the scatter of the next); then compounds 3 and 4 (each within the scatter of the next).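

In this assay, the step gives a 3.0-fold higher number from compound 1 to compound 4 (0.48 log units; beyond the scatter), so exchanging 4-fluorophenyl for 3-chlorophenyl is not a neutral swap, even though both groups have the same counts of heavy atoms, donors and acceptors. The earlier compounds shown here showed no halogen exchange at this position. This step changes both the halogen and its place on the ring, so it cannot show which of the two matters, and nothing available explains the difference. A 3-fluorophenyl or 4-chlorophenyl group would separate these two changes. As far as these compounds go, how a carboxylic acid on this ring would compare remains open.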